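The source may report more compounds than this note shows. Statements on the series, on what has been measured and on what is new or still open speak of the compounds shown alone.

In an in vitro ADME assay on microsomes from Gut (Homo sapiens) for metabolic stability, using NADPH (on this read-out higher numbers stand for fast clearance and lower numbers for slow clearance), compound 1 (`COc1ccc(Cl)cc1Cn1c(C(=O)NCC(C)(C)CO)cc2cc(C#N)ccc21`) gives < 6 mL.min-1.g-1, which is a limit of the assay and not a number. Compound 2 (`COc1ccc(C)cc1Cn1c(C(=O)NCC(C)(C)CO)cc2cc(C#N)ccc21`) gives < 6 mL.min-1.g-1, also a limit. Compound 1 therefore stands at the limit of < 6 mL.min-1.g-1 in this assay, at which 2 of the 3 values shown sit. Methyl in place of chloro gives a step that the two limits leave unreadable from compound 1 to compound 2. Compound 3 (`CCCOc1cccc(Cn2c(C(=O)NCC(C)(C)CO)cc3cc(C#N)ccc32)c1`) gives a true number, 13 mL.min-1.g-1.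

Compound 4 (`COc1ccc(Cl)cc1Cn1c(C(=O)NCC2(CO)CCC2)cc2cc(C#N)ccc21`) keeps the 5-chloro-2-methoxyphenyl of compound 1 and changes only the other end of the molecule: 1-(hydroxymethyl)cyclobutyl in place of 1-(hydroxymethyl)-1-methylethyl on a saturated chain carbon bound to an amide-type nitrogen. Going by the values given here, no measured step touches this place. Both readable steps, an at least 2.1-fold higher number from compound 1 to compound 3 (0.33 log units; beyond the scatter) and an at least 2.1-fold higher number from compound 2 to compound 3 (0.33 log units; beyond the scatter), replace the aromatic group on a saturated chain carbon bound to an aromatic nitrogen. Compound 4 leaves that group untouched, so a rise of that kind is not expected. The expected step is a number no lower from compound 1 to compound 4 (the limit leaves the size open), an estimate with no clear direction beyond the scatter. For compound 4 the estimated clearance is 6 mL.min-1.g-1, with an expected range from 3 mL.min-1.g-1 to 13 mL.min-1.g-1.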

Compound 4, intrinsic clearance in microsomes: < 6 mL.min-1.g-1
Compound 4: no number, only a limit; the forecaster's own chance of this, stated with the estimate: 55%; the middle value sits exactly at the limit.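

In this assay, compound 1 and compound 4 each give a limit and not a number, so no step can be read between them: the limit of < 6 mL.min-1.g-1 in this assay, at which 3 of the 4 values shown sit. From the compounds shown here alone, how far 1-(hydroxymethyl)cyclobutyl in place of 1-(hydroxymethyl)-1-methylethyl changes the clearance, if at all, stays open.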